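Phenyl substituent variation on the shared core

The source may hold more compounds than are shown below. What is called first, only, known or untested is meant among the compounds shown, and "the series" means these compounds.

In a functional assay, with a stated time of 20 min (a lower number here means a stronger inhibitor, a higher number a weaker inhibitor), compound 1 `CCOC(=O)c1cnn(-c2nc(-c3ccccc3Cl)c(C#N)c(=O)n2C)c1N` gives 78 ug/mL, compound 2 `CCOC(=O)c1cnn(-c2nc(-c3ccc(OC)cc3)c(C#N)c(=O)n2C)c1N` gives 59 ug/mL and compound 3 `CSc1nc(-c2ccc(N(C)C)cc2)c(C#N)c(=O)n1C` gives 78 ug/mL. Compound 2 holds the lowest of the three numbers, but its gaps to compound 1 and to compound 3 both lie within the scatter, so no order among them is claimed. Among the measured compounds shown here, the single measured step on the aryl group, a 1.3-fold lower number from compound 1 to compound 2 (0.12 log units; within the scatter), is itself within the scatter. Compound 4 `CCOC(=O)c1cnn(-c2nc(-c3ccccc3O)c(C#N)c(=O)n2C)c1N` differs from compound 2 as follows: 2-hydroxyphenyl in place of 4-methoxyphenyl on an aromatic carbon. For the measured compounds named here, that aryl step is the only one bearing on this change, and nothing in it points to a move beyond the scatter. The expected step in this assay is therefore a 1.1-fold higher number from compound 2 to compound 4 (0.04 log units; within the scatter). Compound 4 is estimated at 65 ug/mL, with a range from 30 ug/mL to 140 ug/mL.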

Compound 4, half-maximal inhibitory concentration: 48 ug/mL
For compound 4 the middle estimate is 1.4-fold (0.13 log units) above the measured one; the range from low to high includes it.
By their numbers in this assay, from the lowest: compounds 4, 2, 1 and 3 (each within the scatter of the next).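

In this assay, the step to 2-hydroxyphenyl in place of 4-methoxyphenyl (a 1.2-fold lower number from compound 2 to compound 4 (0.09 log units; within the scatter)) and the step to hydroxy in place of chloro (a 1.6-fold lower number from compound 1 to compound 4 (0.21 log units; within the scatter)) both stay within the scatter. This aryl position on the shared core therefore takes a group with a hydrogen-bond donor without a step beyond the scatter, and compounds 1, 2 and 4 are not separated. No evidence available here bears on this result.

As far as these compounds go, whether an amine or a carboxylic acid on this aryl group would give a step beyond the scatter remains open.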